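The source may hold more compounds than are shown below. What is called first, only, known or untested is meant among the compounds shown, and "the series" means these compounds.

Working notes on the series. Compound 3 `CNc1ncnc2c1c(-c1ccco1)cn2[C@@H]1O[C@H](CO)[C@@H](O)[C@H]1O` gives 850 nM in a functional assay on HepG2 cells (Homo sapiens) for antiproliferative activity, read by XTT assay, with a stated time of 72 h (a higher number here means a weaker inhibitor, a lower number a stronger inhibitor), the lowest of the two numbers available, and compound 1 `C#Cc1cn([C@@H]2O[C@H](CO)[C@@H](O)[C@H]2O)c2ncnc(OC)c12`, at 12700 nM, stands beyond the scatter from it. Compound 2 `CSc1ncnc2c1c(-c1ccsc1)cn2[C@@H]1O[C@H](CO)[C@@H](O)[C@H]1O` gives only a limit, > 15000 nM.

Compound 4 `CNc1ncnc2c1c(-c1cc3ccccc3o1)cn2[C@@H]1O[C@H](CO)[C@@H](O)[C@H]1O` is the next to be read. It carries 1-benzofuran-2-yl in place of the furan-2-yl of compound 3, on an aromatic carbon of a five-membered aromatic ring with 1 nitrogen (1-benzofuran-2-yl in place of furan-2-yl on an aromatic carbon). The entering group keeps the five-membered aromatic ring with 1 hetero atom and adds one six-membered aromatic ring of carbon only.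

Within the data shown here, no two measured compounds differ in one place only, so this step has no direct precedent. With compound 3 at 850 nM, the low end of what has been seen, a change at this place is expected to raise the number in this assay, probably beyond the scatter. A limit is also possible for the new compound, given (the limit of > 15000 nM in this assay, at which 1 of the 3 values shown sits).

The expected step is a 3.5-fold higher number from compound 3 to compound 4 (0.55 log units; beyond the scatter). For compound 4 the estimate is 3000 nM, with an expected range of 700 nM to 12000 nM.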

Compound 4, half-maximal inhibitory concentration: > 20000 nM
Compound 4 was reported as a limit; the forecaster's own chance of this, stated with the estimate: 25%; at least 6.6-fold (0.82 log units) between middle value and limit.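

In this assay compound 4 is read only as a limit and not as a number: the limit of > 20000 nM in this assay, at which 1 of the 4 values shown sits.

Among these compounds, putting 1-benzofuran-2-yl in place of furan-2-yl, which adds one six-membered aromatic ring of carbon only, gives an at least 23-fold higher number from compound 3 to compound 4 (1.37 log units; beyond the scatter), the first step between compounds that differ in one place. This pair shows that the read-out at this aromatic carbon depends strongly on the group it carries, which compounds 1, 2 and 3, differing from one another in more than one place, could not show.

On these data alone, whether a phenyl group at this place would also give a large step from compound 3 stays open, so the pair does not separate the effect of the added ring from that of the furan-2-yl group being replaced. Also open, as far as these compounds go, is whether the same exchange would give a step of similar size on a core carrying a dimethylamino group in place of the amine shared by compound 3 and compound 4.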